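Swapping a ring-bearing side chain for isopropyl

The compounds below may be only part of what the source reports. "The series", "measured", "known", "first", "only" and "open" are said of these compounds alone.

Measured so far:
- compound 1 `Cn1cc(-c2ccc(NC(=O)c3cn(CC4CCCO4)cc(-c4ccc(F)cc4)c3=O)cc2)c2c(N)ncnc21`: 1.2 nM
- compound 2 `Cn1cc(-c2ccc(NC(=O)c3cn(CC4CCOCC4)cc(-c4ccc(Cl)cc4)c3=O)cc2)c2c(N)ncnc21`: 0.2 nM
- compound 3 `CC(C)n1cc(C(=O)Nc2cc(F)c(-c3c[nH]c4ncnc(N)c34)cc2F)c(=O)c(-c2ccc(F)cc2)c1`: < 0.2 nM

All three were tested in an assay on isolated protein for inhibition of tyrosine-protein kinase receptor UFO (Homo sapiens), read by ELISA; on this read-out higher numbers stand for weaker inhibition and lower numbers for stronger inhibition. Compound 1 gives 1.2 nM, the highest of the two plain numbers. Compound 2 gives 0.2 nM, a lower value, and the gap between these two lies beyond the usual scatter of repeated measurements. Compound 3 is reported only as a limit, < 0.2 nM, which means its value lies past the reach of the assay rather than at a fixed number.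

The unmeasured compound 4 `CC(C)n1cc(C(=O)Nc2ccc(-c3cn(C)c4ncnc(N)c34)cc2)c(=O)c(-c2ccc(F)cc2)c1` keeps the shared core of compound 1 and changes one group: isopropyl in place of (oxolan-2-yl)methyl on an aromatic nitrogen. Compound 3 also carries an isopropyl on this position and sits at the limit, (the limit of < 0.2 nM in this assay, at which 1 of the 3 values shown sits). On that basis compound 4 is expected to land lower than compound 1, and the step of a 4.0-fold lower number from compound 1 to compound 4 (0.60 log units; beyond the scatter) is the estimated size of that move. Compound 4 is therefore expected to give about 0.3 nM, with a likely range from 0.1 nM to 1 nM.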

Compound 4, half-maximal inhibitory concentration: 0.4 nM
Compound 4: the middle estimate sits 1.3-fold (0.12 log units) below what was measured; measured number inside the range.
By their numbers in this assay, from the lowest: compounds 2 and 4 (each within the scatter of the next); then compound 1.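

In this assay, among these compounds, putting isopropyl in place of (oxolan-2-yl)methyl on the aromatic nitrogen gives a 3.0-fold lower number from compound 1 to compound 4 (0.48 log units; beyond the scatter), the first reading of this change with the rest of the molecule held fixed. At this position, then, the five-membered non-aromatic ring and its oxygen are not needed for strong inhibition on this core, since a smaller group with no ring and no hydrogen-bond acceptor does modestly better. The data shown give no measured reason for this step.

This single pair cannot separate the loss of the ring from the loss of the oxygen or the drop in size. Cyclopentylmethyl would keep the ring without the oxygen and 2-methoxyethyl the oxygen without the ring, so the effect of each on its own remains open.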